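The compounds below may be only part of what the source reports. "The series", "measured", "known", "first", "only" and "open" are said of these compounds alone.

Compound 3 `Cc1ccccc1CNCC1(O)CCN(CCCc2c[nH]c3ccc(-n4cnnc4)cc23)CC1` is the weakest of the three measured compounds in an assay on CHO cells with 5-hydroxytryptamine receptor 1D (Homo sapiens) as the target (on this read-out higher numbers stand for weaker inhibition and lower numbers for stronger inhibition), where compound 3 gives 4 nM. Compound 1 `OC1(CNCc2ccccc2)CCN(CCCc2c[nH]c3ccc(-n4cnnc4)cc23)CC1` gives 0.45 nM in this assay, and compound 2 `CN(CC(C)(C)C)CC1(O)CCN(CCCc2c[nH]c3ccc(-n4cnnc4)cc23)CC1` gives 1.8 nM. The gap between the two ends is an 8.9-fold higher number from compound 1 to compound 3 (0.95 log units; beyond the scatter), the nearest neighbour of compound 3 is reached by a 2.2-fold higher number from compound 2 to compound 3 (0.35 log units; beyond the scatter), and the two more potent compounds are separated by a 4.0-fold higher number from compound 1 to compound 2 (0.60 log units; beyond the scatter).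

Compound 4 `CC(C)(C)OC(=O)NCC1(O)CCN(CCCc2c[nH]c3ccc(-n4cnnc4)cc23)CC1` differs from compound 3 by tert-butoxycarbonyl in place of 2-methylbenzyl on an amine nitrogen. All three measured steps change what sits on this amine nitrogen, and each raised the number only modestly, but none of them exchanges a ring-bearing group for a tert-butoxycarbonyl, so they bear on the present step only as a sign that this position is sensitive. Within the data shown here, the series offers no direct precedent for a carbamate here. He therefore expects compound 4 to move further in the weaker direction in this assay, by a step of a 5.0-fold higher number from compound 3 to compound 4 (0.70 log units; beyond the scatter), with wide uncertainty. His estimate for compound 4 is 20 nM, within a range from 4 nM to 100 nM.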

Compound 4, half-maximal inhibitory concentration: 21 nM
Compound 4: the middle estimate sits 1.1-fold (0.02 log units) below what was measured, and the stated range covers the measured number.
By their numbers in this assay, from the lowest: compound 1; then compound 2; then compound 3; then compound 4.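

Swapping 2-methylbenzyl for tert-butoxycarbonyl on the amine nitrogen gives the largest change yet from compound 3 in this assay (a 5.3-fold higher number from compound 3 to compound 4 (0.72 log units; beyond the scatter)), and the reach of this position now extends well past the earlier modest steps (a 47-fold higher number from compound 1 to compound 4 (1.67 log units; beyond the scatter)). Compound 2 also has no ring in this group, yet the step from it is large (a 12-fold higher number from compound 2 to compound 4 (1.07 log units; beyond the scatter)), so among these compounds the absence of the aromatic ring does not by itself go with the high number seen for compound 4, which alone has a carbonyl and two hydrogen-bond acceptors in this group. No measurement shown here gives a reason for this loss.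

These compounds cannot separate the part played by the carbonyl from that of the tert-butyl group, and an acetyl amide or a benzyl carbamate on this nitrogen would pull the two apart. From the compounds shown here alone, it also remains open where the unsubstituted primary amine, with only hydrogen on this nitrogen, would fall relative to the benzyl compound 1 and the carbamate compound 4.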